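Cytotoxicity notes: hydrogen for methyl on the ring nitrogen

The source may report more compounds than this note shows. Statements on the series, on what has been measured and on what is new or still open speak of the compounds shown alone.

Compound 2 `CC(=O)Nc1ccc(-c2nc3cc(C(F)(F)F)ccc3n2C)cc1` gives 15000 nM in an ADME assay on MT4 cells (Homo sapiens) for cytotoxicity, read by MTT assay, with a stated time of 96 h; on this read-out lower numbers stand for higher toxicity in this test and higher numbers for lower toxicity in this test; it stands second highest of the three numbers, nearest compound 1 `CN1CCN(CC(=O)Nc2ccc(-c3nc4cc(C(F)(F)F)ccc4n3C)cc2)CC1` with 22000 nM and furthest from compound 3 `CCC(=O)Nc1ccc(-c2nc3cc(C(F)(F)F)ccc3n2C)cc1` with 8000 nM, both gaps within the scatter. Compound 4 `CC(=O)Nc1ccc(-c2nc3cc(C(F)(F)F)ccc3[nH]2)cc1` differs from compound 2 by hydrogen in place of methyl on an aromatic nitrogen. Among the measured compounds shown here, none of the measured steps touches this position: a 1.5-fold lower number from compound 1 to compound 2 (0.17 log units; within the scatter), a 2.8-fold lower number from compound 1 to compound 3 (0.44 log units; beyond the scatter) and a 1.9-fold lower number from compound 2 to compound 3 (0.27 log units; within the scatter) all concern the saturated chain carbon bound to the carbonyl carbon, and only one reached beyond the scatter. The series gives no guide for a change on the aromatic nitrogen. Compound 4 is therefore expected to show no change at the digits printed from compound 2 to compound 4 (within the scatter), nothing beyond the scatter. Compound 4 is estimated at 15000 nM, with a range from 6000 nM to 40000 nM.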

Compound 4, half-maximal cytotoxic concentration: 19000 nM
The estimate for compound 4 lay 1.3-fold (0.10 log units) below the measured number, and the stated range covers the measured number.
By their numbers in this assay, from the lowest: compounds 3, 2, 4 and 1 (each within the scatter of the next, the first and the last beyond it).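

In this assay hydrogen in place of methyl on the aromatic nitrogen gives a 1.3-fold higher number from compound 2 to compound 4 (0.10 log units; within the scatter) and so stays within the scatter. On this one pair, the methyl on this nitrogen is not needed to keep the number where it stands. Nothing measured here speaks to why the read-out holds at this position.

Open, from the compounds shown here alone, is whether an ethyl group or a longer chain on this nitrogen would leave the number in place. Also open, going by these compounds, is whether the same exchange reads alike with the 4-methylpiperazin-1-yl side chain of compound 1.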